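From methyl to chloro: what compound 3 may show

The source may hold more compounds than are shown below. What is called first, only, known or untested is meant among the compounds shown, and "the series" means these compounds.

Measured so far in a physicochemical assay for solubility, in phosphate buffer, at pH 7.4; on this read-out lower numbers stand for lower solubility and higher numbers for higher solubility
- compound 1 `CCOC(=O)c1c(-c2cccc(C)c2)[nH]c2cc(OC)ccc2c1=O` gives 48000 nM
- compound 2 `CCOC(=O)c1c(-c2cccc(F)c2)[nH]c2cccc(OC)c2c1=O` gives > 100000 nM (a limit of the assay, not a number)

Of these two compounds, only compound 1 has an actual number (48000 nM) in this assay. For compound 2 the reading of > 100000 nM is a limit. Among the measured compounds shown here, the two compounds also differ in more than one place, so no measured step gives a size for a single change on this series.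

The next compound to be measured is compound 3 `CCOC(=O)c1c(-c2cccc(Cl)c2)[nH]c2cc(OC)ccc2c1=O`, which keeps the shared core of compound 1 and changes one group. The change is chloro in place of methyl on an aromatic carbon, so that 3-methylphenyl becomes 3-chlorophenyl.

For the measured compounds named here, with no measured step to guide it, the forecast starts from compound 1 (48000 nM) and allows only a small downward move. The expected change is a 1.2-fold lower number from compound 1 to compound 3 (0.08 log units; within the scatter), which would lie close to the usual scatter of this assay. Compound 3 is estimated at 40000 nM (expected range 15000 nM to 90000 nM).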

Compound 3, solubility: 58000 nM
Compound 3: middle estimate off by 1.5-fold (0.16 log units), on the low side, within the range that was stated.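

In this assay, among the compounds shown here, the swap of chloro in place of methyl on an aromatic carbon, which turns 3-methylphenyl into 3-chlorophenyl, gives the first step on this series that can be read for a change in one place: a 1.2-fold higher number from compound 1 to compound 3 (0.08 log units; within the scatter). At this position, meta to a large group on a six-membered aromatic ring of carbon only, the read-out therefore does not tell methyl and chloro apart, as compound 1 and compound 3 lie within the scatter of each other. Compound 2 remains a limit and not a number, and any step to it cannot be read: the limit of > 100000 nM in this assay, at which 1 of the 3 values shown sits.

The compounds shown leave open whether a group of another kind at this position, such as an amine or a carboxylic acid, would shift the number in this assay beyond the scatter. They also leave the two places in which compound 2 differs from compound 1 unseparated, so neither place has a size of its own on this read-out.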